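The source may report more compounds than this note shows. Statements on the series, on what has been measured and on what is new or still open speak of the compounds shown alone.

In a functional assay on MCF7 cells (Homo sapiens) for cytotoxicity, read by MTT assay, with a stated time of 24 h (on this read-out higher numbers stand for weaker inhibition and lower numbers for stronger inhibition), three compounds have been read so far, and none gives a number. Compound 1 (`CCOC1C=C(CC[C@]2(C)[C@@H](C)CC[C@@]3(C)C(C(=O)O)=CC=C[C@@H]23)C(=O)O1`) gives > 40000 nM as a limit of the assay. Compound 2 (`CCOC1C=C(CC[C@]2(C)[C@@H](C)CC[C@@]3(C)C(C(=O)O)=CCC[C@@H]23)C(=O)O1`) gives > 40000 nM as a limit too. Compound 3 (`C=C1CC[C@H](C)[C@@](C)(CCC2=CC(O)OC2=O)C/C=C\C=C/1C(=O)O`) gives > 40000 nM as a limit also, so it stands with the other two at the limit of > 40000 nM in this assay, at which 3 of the 3 values shown sit, and has no exact place. Compound 4 (`C=C1CC[C@H](C)[C@@](C)(CCC2=CC(OC)OC2=O)C/C=C\C=C/1C(=O)O`) departs from compound 3 in one place, hydroxy to methoxy (methyl in place of hydrogen on an oxygen on a saturated carbon), with methyl in place of hydrogen on an oxygen on a saturated carbon. For the measured compounds named here, no measured pair shows this change, so no step beyond the scatter is expected in this assay, and another limit is likely. The estimated step is small (a number no higher from compound 3 to compound 4 (the limit leaves the size open)). For compound 4 the expected value is 40000 nM within an estimated range of 15000 nM to 80000 nM (an expectation only).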

Compound 4, half-maximal inhibitory concentration: > 40000 nM
Compound 4 ended at the assay's limit (the forecaster's own chance of this, stated with the estimate: 75%); the middle value sits exactly at the limit.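

Compound 3 and compound 4 both stand only as limits in this assay and so no new step can be read between them. The compounds shown leave open what exact values they have and what hydroxy to methoxy does.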